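Shrinking the Ring on the Amine Substituent

This account rests on a few compounds, and the source may have more. Where it says the series, first, only, none or still open, it means among the compounds named here.

Compound 1 `CO[C@H]1CC[C@@H](Nc2cc(NCc3cnccc3C(F)(F)F)ncc2C#N)CC1`: 58 nM
Compound 2 `N#Cc1cnc(NCc2cnccc2C(F)(F)F)cc1NC1CCOCC1`: 900 nM
Compound 3 `CC1(C)C[C@@H](Nc2cc(NCc3cnccc3C(F)(F)F)ncc2C#N)CC[C@H]1O`: 120 nM

In an assay on isolated protein for inhibition of protein kinase C theta type (Homo sapiens), read by TR-FRET, with a stated time of 2 h (on this read-out lower numbers stand for stronger inhibition and higher numbers for weaker inhibition), compound 3 stands second highest of the three numbers: the step of a 2.1-fold higher number from compound 1 to compound 3 (0.32 log units; beyond the scatter) is modest, whereas a 7.5-fold lower number from compound 2 to compound 3 (0.88 log units; beyond the scatter) is larger, and a 16-fold higher number from compound 1 to compound 2 (1.19 log units; beyond the scatter) shows how strongly this assay responds to the group on that nitrogen. Compound 4 `CC1(C)[C@@H](Nc2cc(NCc3cnccc3C(F)(F)F)ncc2C#N)C[C@@H]1C(N)=O` differs from compound 3 by 3-carbamoyl-2,2-dimethylcyclobutyl in place of 4-hydroxy-3,3-dimethylcyclohexyl on a nitrogen on an aromatic ring. Among the compounds with values here, no measured step changes ring size or introduces a carbamoyl, so the measured steps only set the scale of what swapping this group can do. A modest weakening beyond the scatter is expected, with wide uncertainty. Compound 4 is expected to give 300 nM, in the range 60 nM to 1500 nM. That estimate means a step of a 2.5-fold higher number from compound 3 to compound 4 (0.40 log units; beyond the scatter).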

Compound 4, half-maximal inhibitory concentration: 1100 nM
Estimate against measurement, compound 4: 3.7-fold (0.56 log units) below; measured number inside the range.
By their numbers in this assay, from the lowest: compound 1; then compound 3; then compounds 2 and 4 (each within the scatter of the next).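

In this assay, the first change of ring size at this nitrogen, to 3-carbamoyl-2,2-dimethylcyclobutyl, comes with a clear loss (a 9.2-fold higher number from compound 3 to compound 4 (0.96 log units; beyond the scatter)) and a larger gap to the best compound shown (a 19-fold higher number from compound 1 to compound 4 (1.28 log units; beyond the scatter)). Against the oxan-4-yl group, the same group gives no readable difference (a 1.2-fold higher number from compound 2 to compound 4 (0.09 log units; within the scatter)), so two unlike groups land level. No evidence here explains this loss.

Ring size and the carbamoyl changed together, so their shares remain open. A cyclohexyl bearing a carbamoyl, or a cyclobutyl bearing a hydroxyl, would separate them.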